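Working notes on cytotoxicity across four compounds

The source may hold more compounds than are shown below. What is called first, only, known or untested is meant among the compounds shown, and "the series" means these compounds.

Compound 1 `CSc1ccc(NC(=O)Nc2cc(C)nc3ccccc23)cc1` and compound 3 `Cc1cc(NC(=O)Nc2ccc(C(N)=O)cc2)c2ccccc2n1` share one core; compound 2 `CSc1ccccc1NC(=O)Nc1cc(C)nc2ccccc12` and compound 4 `Cc1cc(NC(=O)Nc2ccccc2C(N)=O)c2ccccc2n1` share another. How the core of compound 2 differs from that of compound 1 is not broken down here. In an ADME assay on HEK293 cells (Homo sapiens) for cytotoxicity, with a stated time of 72 h (a lower number here means that less compound is needed, a higher number that more compound is needed for the effect), compound 1 gives 24000 nM. Compound 3 reaches only the limit of > 25000 nM in this assay. The change carbamoyl in place of methylsulfanyl on an aromatic carbon thus yields an at least 1.0-fold higher number from compound 1 to compound 3 (0.01 log units; that floor lies within the scatter). Compound 2 likewise sits at the limit of > 25000 nM. Because (the limit of > 25000 nM in this assay, at which 2 of the 3 values shown sit), the measured step is only a floor. The change carbamoyl in place of methylsulfanyl on an aromatic carbon is the same kind of change, but here the carbamoyl stands ortho to a large group rather than para to it. For compound 4 a step that the limit leaves unreadable from compound 2 to compound 4 is expected, resting on the same change having given an at least 1.0-fold higher number from compound 1 to compound 3 (0.01 log units; that floor lies within the scatter). Compound 4 is estimated at 32000 nM, between 20000 nM and 70000 nM, with a limit the more probable outcome.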

Compound 4, half-maximal effective concentration: > 25000 nM
Compound 4 gave a limit, no number; the forecaster's own chance of this, stated with the estimate: 80%; the middle value lies beyond the limit too.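

No step can be read from compound 2 to compound 4, since both stand at a limit: the limit of > 25000 nM in this assay, at which 3 of the 4 values shown sit. Still open, going by these compounds, is how far carbamoyl in place of methylsulfanyl, ortho to a large group, shifts the number in this assay at all.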